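Swapping benzyl for 4-methylphenyl on the amide nitrogen

The source may hold more compounds than are shown below. What is called first, only, known or untested is meant among the compounds shown, and "the series" means these compounds.

Measured compounds, cytotoxicity in an ADME assay on WI-38 cells (Homo sapiens) for cytotoxicity, read by MTT assay, with a stated time of 72 h; on this read-out higher numbers stand for weaker inhibition and lower numbers for stronger inhibition:
Compound 1 `O=C(O)CCc1cccc2c1B(O)OC2`: > 100000 nM, a limit of the assay rather than a number.
Compound 2 `O=C(CCc1cccc2c1B(O)OC2)NCc1ccccc1`: > 100000 nM, likewise a limit of the assay.

For the measured compounds named here, compound 2 stands at the limit of > 100000 nM in this assay, at which 2 of the 2 values shown sit, so no step between the two measured compounds can be sized. Compound 3 `Cc1ccc(NC(=O)CCc2cccc3c2B(O)OC3)cc1` differs from compound 2 by 4-methylphenyl in place of benzyl on an amide-type nitrogen. Going by the values given here, with no measured step to build on, the expected change a step that the limit leaves unreadable from compound 2 to compound 3 is none beyond the scatter. Compound 3 is therefore expected to give 150000 nM, within 50000 nM to 500000 nM, most likely reported again only as a limit.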

Compound 3, half-maximal inhibitory concentration: > 100000 nM
Compound 3: no number, only a limit; the forecaster's own chance of this, stated with the estimate: 85%; the middle value lies beyond the limit too.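

The change from compound 2 to compound 3 cannot be sized, because both values are limits rather than numbers: the limit of > 100000 nM in this assay, at which 3 of the 3 values shown sit.

The compounds shown leave open whether 4-methylphenyl and benzyl on the amide-type nitrogen differ at all in this assay.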